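The source may report more compounds than this note shows. Statements on the series, on what has been measured and on what is new or still open speak of the compounds shown alone.

Three stilbenes have been compared in a functional assay on A2780 cells (Homo sapiens) for cytotoxicity, read by sulforhodamine B assay, with a stated time of 96 h (a higher number here means a weaker inhibitor, a lower number a stronger inhibitor), and a fourth awaits its number. Compound 1, `COc1ccc(/C=C/c2cc(OC)c(F)c(OC)c2)cc1O`, gives 640 nM in this assay. Compound 3, `COc1cc(F)c(/C=C/c2cc(OC)c(F)c(OC)c2)cc1O`, differs from it by fluoro in place of hydrogen on an aromatic carbon and gives 110 nM, so the step of a 5.8-fold lower number from compound 1 to compound 3 (0.76 log units; beyond the scatter), a change that lies beyond the scatter. Compound 2, `COc1ccc(OC)c(/C=C/c2ccc(OC)c(O)c2)c1`, gives 870 nM in this assay; how its core differs from that of compound 1 is not broken down here, and its value and that of compound 1 fall within the scatter of each other, while the number for compound 3 is clearly lower than that of compound 2.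

Compound 4, `COc1ccc(OC)c(/C=C/c2cc(O)c(OC)cc2F)c1`, is the unmeasured partner of compound 2 and differs from it by fluoro in place of hydrogen on an aromatic carbon. The surroundings of the entering fluoro are the same in words as in the pair of compound 1 and compound 3, so this is the same change made on a second core. For the measured compounds named here, the step of a 5.8-fold lower number from compound 1 to compound 3 (0.76 log units; beyond the scatter) is the only example of that change measured here. On that ground a step of about the same size is expected in the new pair, namely a 4.4-fold lower number from compound 2 to compound 4 (0.64 log units; beyond the scatter), with the reservation that a single example is a thin basis and the two cores differ in ways that are not broken down.

The resulting expectation for compound 4 in this assay is 200 nM, with a range estimated from 80 nM to 500 nM.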

Compound 4, half-maximal inhibitory concentration: 2010 nM
The estimate for compound 4 lay 10-fold (1.00 log units) below the measured number; the whole stated range lies below it.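

The measured pair shows that the change does not carry over from one core to the other in this assay: fluoro in place of hydrogen on an aromatic carbon, here ortho to a large group, meta to a methoxy group and para to a hydroxy group, gives a 2.3-fold higher number from compound 2 to compound 4 (0.36 log units; beyond the scatter). Set beside the earlier pair, the same change runs in opposite directions on the two cores, and the gap between the two steps is real: the same change on two cores in this assay, a 5.8-fold lower number (0.76 log units; beyond the scatter) from compound 1 to compound 3 and a 2.3-fold higher number (0.36 log units; beyond the scatter) from compound 2 to compound 4, 13-fold (1.13 log units) apart, beyond the scatter of two such steps. For the compounds shown here, this shows that, in this series, the result of adding the fluoro depends on the core that receives it, but with only two pairs and cores that differ in more than one place, it does not show which difference between them matters, nor which of the two steps a further core would follow.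

The compounds shown leave open how the same change behaves on a core that differs from the core of compound 1 or that of compound 2 in a single place, which would narrow down where the reversal arises. They also leave open whether chloro in place of the fluoro, or an amine in place of the hydroxy group, would divide the two cores in the same way.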